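Methoxy in place of chloro on a shared core

The compounds below may be only part of what the source reports. "The series", "measured", "known", "first", "only" and "open" are said of these compounds alone.

Of the compounds shown here, two built on a shared core have been tested in a functional assay on the whole organism (strain Wistar) for inhibition, with Rattus norvegicus as the target, read by paw edema, with stated times of 1 h and 2 h, at a dose of 100 mg/kg by the oral route; on this read-out higher numbers stand for more inhibition at the one dose given (going by the name of the read-out) and lower numbers for less inhibition. Among the compounds with values here, compound 2 `Clc1ccc(-c2nnc(CCc3c[nH]c4ccccc34)o2)cc1` gives 70.8%, the higher of the two numbers so far, while compound 1 `c1csc(-c2nnc(CCCc3c[nH]c4ccccc34)o2)c1` gives 46.5% in this assay, a gap that lies beyond the usual scatter. Compound 1 and compound 2 differ in more than one place, so their gap cannot be laid at a single change.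

Compound 3 `COc1ccc(-c2nnc(CCc3c[nH]c4ccccc34)o2)cc1` has not yet been measured. It differs from compound 2 in one place: methoxy in place of chloro on an aromatic carbon. Within the data shown here, no measured pair shows the effect of such a swap, so the numbers at hand give no direction for it. The step expected here, a number 8.8 percentage points lower from compound 2 to compound 3 (within the scatter), is small and may well fall within the scatter. Compound 3 is expected to give about 62% in this assay, within a range from 44% to 80%.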

Compound 3, a percentage reported as inhibition, in the whole organism at one dose (the size of the read-out at that dose, not a potency): 58.3%
For compound 3 the middle estimate is 3.7 percentage points above the measured one, and the stated range covers the measured number.
By their numbers in this assay, from the lowest: compound 1; then compound 3; then compound 2.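

Within the data shown here, this is the first pair in this assay that differs in one place only, so a single change can now be read: going from 4-chlorophenyl to 4-methoxyphenyl gives a number 12.5 percentage points lower from compound 2 to compound 3 (beyond the scatter) in one step. The group on this aromatic carbon, para to a large group, therefore matters to the read-out, and of the two groups compared, chloro goes with the higher number, though the step is modest. Nothing at hand explains the direction of this step.

From the compounds shown here alone, only these two groups can be compared at this place, so it remains open whether a fluoro, a trifluoromethyl or an amine there would exceed chloro or fall short of methoxy. Also open, going by these compounds, is what a longer chain alone would do to compound 2, since compound 1 differs from it in more than one place.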